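The source may report more compounds than this note shows. Statements on the series, on what has been measured and on what is new or still open speak of the compounds shown alone.

Compound 1 `Cc1ccc(S/C(=C/c2ccc(Br)cc2)C(=O)c2ccc(Cl)cc2)cc1` is the weakest of the three compounds measured in a functional assay on DU-145 cells (Homo sapiens) for inhibition, read by trypan blue exclusion, with a stated time of 96 h; on this read-out lower numbers stand for stronger inhibition of growth and higher numbers for weaker inhibition of growth: compound 1 gives 25000 nM. Its nearest neighbour is compound 3 `Cc1ccc(S/C(=C/c2ccc(Oc3ccccc3)cc2)C(=O)c2ccc(Cl)cc2)cc1`, which in this assay gives 10000 nM; the furthest is compound 2 `O=C(/C(=C\c1ccc(Br)cc1)SCc1ccc(Cl)cc1)c1ccc(Cl)cc1`, which in this assay gives 1000 nM. The step of a 25-fold lower number from compound 1 to compound 2 (1.40 log units; beyond the scatter) is large, while the step of a 2.5-fold lower number from compound 1 to compound 3 (0.40 log units; beyond the scatter) is modest.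

Compound 4 `Cc1ccc(S/C(=C/c2cc(Cl)cc(Cl)c2Cl)C(=O)c2ccc(Cl)cc2)cc1` has not yet been measured. It differs from compound 1 in one place: 2,3,5-trichlorophenyl in place of 4-bromophenyl on a double-bonded chain carbon bound to a double-bonded chain carbon. Going by the values given here, of the two measured steps, only the one to compound 3 touches the same ring, the one on the double-bonded chain carbon; there phenoxy in place of bromo on an aromatic carbon gave a 2.5-fold lower number from compound 1 to compound 3 (0.40 log units; beyond the scatter). The step to compound 2 changes the group on the sulfur instead and does not speak directly to the new ring. Three chlorines in a different arrangement are not the same as one phenoxy, so the direction is uncertain; one would expect no more than a modest change, with a small lowering of the number somewhat more likely than a rise, that is a 2.1-fold lower number from compound 1 to compound 4 (0.32 log units; beyond the scatter). Compound 4 is therefore estimated to give 12000 nM in this assay, within a range from 3000 nM to 40000 nM.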

Compound 4, concentration for 50% growth inhibition: 50000 nM
The estimate for compound 4 lay 4.2-fold (0.62 log units) below the measured number; the measured number lies above the stated range.
By their numbers in this assay, from the lowest: compound 2; then compound 3; then compounds 1 and 4 (each within the scatter of the next).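

In this assay, 2,3,5-trichlorophenyl in place of 4-bromophenyl on a double-bonded chain carbon bound to a double-bonded chain carbon gives a 2.0-fold higher number from compound 1 to compound 4 (0.30 log units; within the scatter), so this larger, more heavily chlorinated ring cannot be told apart from the 4-bromophenyl ring of compound 1 on this read-out. This position has now taken two changes, and of these only the phenoxy change gives a step beyond the scatter, a 2.5-fold lower number from compound 1 to compound 3 (0.40 log units; beyond the scatter), while the change on the sulfur remains much the largest step shown, a 25-fold lower number from compound 1 to compound 2 (1.40 log units; beyond the scatter), so the ring on the double-bonded chain carbon has so far tolerated replacement without a large change in the number. Nothing measured here bears on the reason for this result.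

The compounds shown leave open whether a ring with a single chlorine, or with the same three chlorines in another arrangement, would read any differently, and whether an amine or a carboxylic acid on this ring would move the number further than phenoxy does. They also leave open whether the 4-chlorobenzyl group on the sulfur would give a similar step when combined with the phenoxy or 2,3,5-trichlorophenyl rings.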